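The compounds below may be only part of what the source reports. "The series", "measured", "known", "first", "only" and "open" are said of these compounds alone.

Measured so far in a functional assay on CCRF-CEM cells (Homo sapiens) (a lower number here means a stronger inhibitor, a higher number a weaker inhibitor), are three compounds:

- Compound 1 `Cc1ccc(-c2ncnc3c2ncn3C[C@@H]2C[C@H](CO)c3ccccc32)cc1` gives 1.4 ug/mL
- Compound 2 `CC(C)Nc1ncnc2c1ncn2C[C@@H]1C[C@H](CO)c2ccccc21` gives 24 ug/mL
- Compound 3 `OC[C@H]1C[C@@H](Cn2cnc3c(-c4ccc(Cl)cc4)ncnc32)c2ccccc21` gives 0.63 ug/mL

Compound 3 stands lowest of the three, and its nearest neighbour is compound 1, with the step of a 2.2-fold lower number from compound 1 to compound 3 (0.35 log units; beyond the scatter) being modest. In compound 4 `OC[C@H]1C[C@@H](Cn2cnc3c(NC4CC4)ncnc32)c2ccccc21` cyclopropylamino takes the place of 4-chlorophenyl on an aromatic carbon next to the ring nitrogen (cyclopropylamino in place of 4-chlorophenyl on an aromatic carbon).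

The step of a 38-fold lower number from compound 2 to compound 3 (1.58 log units; beyond the scatter) bears most directly on this change, since it is large and exchanges isopropylamino for the same 4-chlorophenyl. The step of a 17-fold higher number from compound 1 to compound 2 (1.23 log units; beyond the scatter) is also large and likewise puts isopropylamino in place of an aryl group, here 4-methylphenyl. Among these three compounds, neither aryl compound goes against the amino compound having the higher number. No measurement compares cyclopropylamino with isopropylamino directly, so compound 2 serves only as the closest guide. A large step towards a higher number is therefore expected in this assay on leaving compound 3. The estimated move is a 32-fold higher number from compound 3 to compound 4 (1.50 log units; beyond the scatter) and would be similar in size to the reverse of the step from compound 2. Compound 4 is estimated at 20 ug/mL as a middle value, with an expected range from 6 ug/mL to 60 ug/mL as its bounds.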

Compound 4, half-maximal inhibitory concentration: 24 ug/mL
Compound 4: middle estimate off by 1.2-fold (0.08 log units), on the low side; low and high end bracket the measured number.
By their numbers in this assay, from the lowest: compound 3; then compound 1; then compounds 2 and 4 (each within the scatter of the next).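

In this assay, for the compounds shown here, the step of no change at the digits printed from compound 2 to compound 4 (within the scatter) shows what the earlier compounds could not: on the nitrogen at this aromatic carbon, cyclopropyl can stand in place of isopropyl with no change beyond the scatter. The large gap between aryl and amino groups at this position therefore no longer rests on isopropylamino alone, as cyclopropylamino gives a 38-fold higher number from compound 3 to compound 4 (1.58 log units; beyond the scatter) and also a 17-fold higher number from compound 1 to compound 4 (1.23 log units; beyond the scatter). Among these four compounds, both aryl compounds have lower numbers than both amino compounds, and no compound goes against this pattern, although it rests on only two groups of each kind.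

No evidence is available to explain the gap between the aryl and amino groups or the lack of change between the two amino groups. The compounds shown leave open whether an unsubstituted amine or a longer chain on that nitrogen would stay level with compound 2 and compound 4, and whether any amino group at this position could reach the low numbers of the two aryl compounds.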